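Chloro to fluoro on the benzyl thioether arm

The source may report more compounds than this note shows. Statements on the series, on what has been measured and on what is new or still open speak of the compounds shown alone.

Three compounds have been measured in a functional assay on the whole organism (artery, strain albino) with Rattus norvegicus as the target, with a stated time of 900 min, at a dose of 10 mg/kg by the oral route; a higher number here means more inhibition at the dose given (going by the name of the read-out), a lower number less inhibition:

Compound 1, `COc1ccc(C2N=C(SCc3ccc(Cl)cc3)NC(C)=C2C(=O)Nc2ccc(Br)cc2)cc1`: 20%
Compound 2, `COc1ccc(C2N=C(SCc3ccc(F)cc3)NC(C)=C2C(=O)Nc2ccc(Br)cc2)cc1`: 15.4%
Compound 3, `CC1=C(C(=O)Nc2ccc([N+](=O)[O-])cc2)C(c2cccc([N+](=O)[O-])c2)N=C(SCc2ccc(Cl)cc2)N1`: 12.3%

Compound 1 and compound 2 share one core and differ only by fluoro in place of chloro on an aromatic carbon. This change gave a number 4.6 percentage points lower from compound 1 to compound 2 (within the scatter), so the two readings cannot be told apart. Compound 3 carries a different core; how it differs from compound 1 is not broken down here, and its reading sits within the scatter of both compound 1 and compound 2.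

Compound 4, `CC1=C(C(=O)Nc2ccc([N+](=O)[O-])cc2)C(c2cccc([N+](=O)[O-])c2)N=C(SCc2ccc(F)cc2)N1`, has not yet been measured. It differs from compound 3 by fluoro in place of chloro on an aromatic carbon, the same change that separates compound 1 from compound 2, made at a place described in identical words.

Going by the values given here, since the one measured example of this change, from compound 1 to compound 2, moved the reading by an amount within the scatter, a step of similar size is expected here: an estimated a number 3.3 percentage points lower from compound 3 to compound 4 (within the scatter), which rests on the fact that the same change produced a number 4.6 percentage points lower from compound 1 to compound 2 (within the scatter). Among the compounds with values here, with only a single prior example, this expectation is loosely held.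

Compound 4 is therefore expected to give about 9%, with a plausible range from 0% to 20%.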

Compound 4, a percentage reported as inhibition, in the whole organism at one dose (the size of the read-out at that dose, not a potency): 15.4%
For compound 4 the middle estimate is 6.4 percentage points below the measured one; measured number inside the range.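

In this assay, fluoro in place of chloro on an aromatic carbon gave a number 3.1 percentage points higher from compound 3 to compound 4 (within the scatter), so compound 3 and compound 4 cannot be told apart. Set beside the earlier example, the two steps also cannot be told apart from each other: the same change on two cores in this assay, a number 4.6 percentage points lower (within the scatter) from compound 1 to compound 2 and a number 3.1 percentage points higher (within the scatter) from compound 3 to compound 4, 7.7 percentage points apart, within the scatter of two such steps On these two cores, the swap carries over in the limited sense that neither step rises above the usual scatter, but this does not show that the change has no effect or that it would behave alike on every core, since two pairs tested at a single dose could hide a small real difference.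

The compounds shown leave open what happens when something other than chloro or fluoro occupies this place on the benzyl ring, such as an amine or a carboxylic acid, or when the benzyl arm is replaced by a longer chain. Going by these compounds alone, they also leave open how much the other features of the two cores contribute, since compound 1 and compound 3 differ in more than one place and no pair here isolates any one of those differences.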